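A few compounds are considered here, and "the series" means these few. Any claim that something is new, unique, unknown or untested is made for them only; others in the source may bear on it.

Of the compounds shown here, two of a shared core have been measured in a functional assay on B16-F10 cells (Mus musculus) for inhibition, read by MTT assay, with a stated time of 72 h; on this read-out higher numbers stand for weaker inhibition and lower numbers for stronger inhibition. Compound 1 `CC(C)c1ccc(-c2nc(SCc3cn(CC(=O)NC(=O)Nc4ccccn4)nn3)nc(Nc3ccccc3Cl)c2C#N)cc1` gives 6790 nM. Compound 2 `Cc1cccc(Nc2nc(SCc3cn(CC(=O)NC(=O)Nc4ccccn4)nn3)nc(-c3ccc(C(C)C)cc3)c2C#N)c1` gives 1650 nM, the lowest of the two numbers; the step of a 4.1-fold lower number from compound 1 to compound 2 (0.61 log units; beyond the scatter) shows how far compound 2 stands from compound 1.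

The unmeasured compound 3 `CC(C)c1ccc(-c2nc(SCc3cn(CC(=O)NC(=O)Nc4ccccn4)nn3)nc(Nc3ccccc3O)c2C#N)cc1` differs from compound 2 in one place: 2-hydroxyphenyl in place of 3-methylphenyl on a nitrogen on an aromatic ring. Going by the values given here, the only measured step, a 4.1-fold lower number from compound 1 to compound 2 (0.61 log units; beyond the scatter), concerns the same nitrogen, where a 2-chlorophenyl was exchanged for a 3-methylphenyl, and it bears on this change only loosely: it shows that the group on that nitrogen can move the number by a modest amount, but no measured compound carries a hydroxyl there, and no measured step tells how a hydroxyl at that place behaves. The estimate therefore rests on that single step and is uncertain.

Compound 3 is expected to give a step of a 1.8-fold higher number from compound 2 to compound 3 (0.26 log units; within the scatter) in this assay, a somewhat higher number than compound 2. Compound 3 is estimated at 3000 nM, with a range from 1000 nM to 10000 nM.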

Compound 3, half-maximal inhibitory concentration: 16100 nM
For compound 3 the middle estimate is 5.4-fold (0.73 log units) below the measured one; measured number above the stated range.
By their numbers in this assay, from the lowest: compound 2; then compound 1; then compound 3.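

In this assay, 2-hydroxyphenyl in place of 3-methylphenyl on the nitrogen gives a 9.8-fold higher number from compound 2 to compound 3 (0.99 log units; beyond the scatter), so the group at this position spans a wider range of numbers than the first pair showed. Hydroxy in place of chloro on an aromatic carbon gives a 2.4-fold higher number from compound 1 to compound 3 (0.37 log units; beyond the scatter), which shows that the 2-substituted ring does not behave the same with both groups and that, of the three groups, 2-hydroxyphenyl goes with the weakest inhibition. Nothing available bears on what lies behind these steps.

The compounds shown change the group and its place on the ring together, so they leave open whether the higher numbers of compound 1 and compound 3 follow from the substituent itself or from where it stands, a question that 2-methylphenyl and 3-hydroxyphenyl on the same nitrogen would help to separate. On these data alone, it also remains open how an unsubstituted phenyl would compare as a baseline, and whether a 2-aminophenyl or a 2-methoxyphenyl would follow the hydroxyl or the chloro compound.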